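The compounds below may be only part of what the source reports. "The series", "measured", "known", "first", "only" and "open" are said of these compounds alone.

The measured compounds are compound 1 `CC(C)Oc1ccccc1-c1cn(C)c(=O)c2[nH]c(C(=O)NCc3ccc(C(=O)Nc4ccccc4N)cc3)cc12`, compound 2 `Cn1cc(-c2ccccc2Oc2ccccc2)c2cc(C(=O)NCCCCC(=O)Nc3ccccc3N)[nH]c2c1=O` and compound 3 `Cn1cc(-c2ccccc2Oc2ccccc2)c2cc(C(=O)NCCCCCCC(=O)Nc3ccccc3N)[nH]c2c1=O`. In a functional assay on MV4-11 cells (Homo sapiens) for antiproliferative activity, read by CCK-8 assay, with a stated time of 72 h (a higher number here means a weaker inhibitor, a lower number a stronger inhibitor), compound 1 gives 130 nM, compound 2 gives 240 nM and compound 3 gives 130 nM. Compound 1 stands level with compound 3, the two sharing the lowest number of the three, and compound 2 lies within the scatter of both, as the step of a 1.8-fold lower number from compound 2 to compound 3 (0.27 log units; within the scatter) shows.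

The unmeasured compound 4 `COc1ccc(-c2cn(C)c(=O)c3[nH]c(C(=O)NCc4ccc(C(=O)Nc5ccccc5N)cc4)cc23)cc1` differs from compound 1 in one place: 4-methoxyphenyl in place of 2-isopropoxyphenyl on an aromatic carbon. Within the data shown here, no measured step touches this part of the shared core; the only step known alters the chain at the far end. The expectation therefore rests on compound 1 alone and carries a wide range. Compound 4 is estimated at 200 nM, between 70 nM and 600 nM. That estimate means a step of a 1.5-fold higher number from compound 1 to compound 4 (0.19 log units; within the scatter), expected to stay within the scatter.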

Compound 4, half-maximal inhibitory concentration: 320 nM
Compound 4: the middle estimate sits 1.6-fold (0.20 log units) below what was measured; the range from low to high includes it.
By their numbers in this assay, from the lowest: compounds 1, 3, 2 and 4 (each within the scatter of the next, the first and the last beyond it).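

Changing this aryl group on the shared core does register in this assay: 4-methoxyphenyl in place of 2-isopropoxyphenyl gives a 2.5-fold higher number from compound 1 to compound 4 (0.39 log units; beyond the scatter). Both groups count one aromatic ring and one hydrogen-bond acceptor, so those counts do not separate them, though the entering group has fewer heavy atoms. Nothing measured here accounts for the step. The change alters the group's size and where its oxygen sits together, so the compounds shown leave open which matters. As far as these compounds go, a 2-methoxyphenyl group would help separate the two, and an amine on this ring remains untested here.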